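Swapping the aryl group in a series measured for glutathione S-transferase P inhibition

The source may hold more compounds than are shown below. What is called first, only, known or untested is meant among the compounds shown, and "the series" means these compounds.

Measured so far:
compound 1, `COc1ccccc1/C=C1\CN(CC(=O)O)c2c(C)cccc2C1=O`, 4.72%
compound 2, `Cc1cc(C)cc(/C=C2\CN(CC(=O)O)c3c(C)cccc3C2=O)c1`, 17.5%

Among the measured compounds shown here, in an assay on HL-60 cells for inhibition of glutathione S-transferase P (Homo sapiens), read by spectrophotometry, tested at 20 uM (a lower number here means less inhibition, a higher number more inhibition at the concentration tested (going by the name of the read-out)), compound 2 gives the higher of the two numbers; its nearest neighbour is compound 1, and the only measured step is a number 12.8 percentage points higher from compound 1 to compound 2 (beyond the scatter). Compound 3, `Cc1cccc2c1N(CC(=O)O)C/C(=C\c1cccc(O)c1)C2=O`, has not yet been tested. It differs from compound 2 in one place: 3-hydroxyphenyl in place of 3,5-dimethylphenyl on a double-bonded chain carbon bound to a double-bonded ring carbon. For the measured compounds named here, the one measured step concerns a different exchange of aryl groups, so it bears on the new change only loosely: it shows that replacing the aryl group in this position can shift this assay by a modest amount. Nothing measured tells in which direction a hydroxyl-bearing ring will move the number. For compound 3 a step of a number 7.5 percentage points lower from compound 2 to compound 3 (within the scatter) is expected, a modest fall that stays close to compound 2. Compound 3 is therefore estimated at 10%, with a range from 1% to 24%.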

Compound 3, a percentage reported as inhibition, at one concentration (the size of the read-out at that concentration, not a potency): 75.6%
Beside the measured number, compound 3's estimate is 65.6 percentage points below it, outside the stated range (above it).
By their numbers in this assay, from the lowest: compound 1; then compound 2; then compound 3.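

In this assay, the aryl group on a double-bonded chain carbon bound to a double-bonded ring carbon can matter far more than the first pair suggested: 3-hydroxyphenyl in place of 3,5-dimethylphenyl gives a number 58.1 percentage points higher from compound 2 to compound 3 (beyond the scatter), and 3-hydroxyphenyl in place of 2-methoxyphenyl gives a number 70.9 percentage points higher from compound 1 to compound 3 (beyond the scatter). Both steps are large, yet the first exchange alters the group only slightly in size, going from 8 heavy atoms to 7 and from 0 hydrogen-bond donors to 1. Nothing available explains this rise.

The compounds shown leave open whether the gain comes with the hydroxyl itself or with the loss of the two methyl groups, a question that an unsubstituted phenyl group could help to settle. Going by these compounds, it also remains open whether an amine or a carboxylic acid in place of the hydroxyl would keep the number high.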